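Iodo for bromo in a cytotoxic series

The compounds below may be only part of what the source reports. "The series", "measured", "known", "first", "only" and "open" are said of these compounds alone.

Among the measured compounds shown here, in a functional assay on PC-3 cells (Homo sapiens) for cytotoxicity, read by sulforhodamine B assay, with a stated time of 72 h (a lower number here means a stronger inhibitor, a higher number a weaker inhibitor), compound 2 `CCCCC/C=C\C[C@@]1(O)C=C(Br)C(=O)/C1=C\C=C\CCCC(=O)OC` gives 500 nM, the lowest of the two numbers so far, and compound 1 `CCCCC/C=C\C[C@@]1(O)C=C(I)C(=O)/C1=C/C=C/CCCC(=O)OC` gives 3900 nM, a gap beyond the scatter. Compound 3 `CCCCC/C=C\C[C@@]1(O)C=C(I)C(=O)/C1=C\C=C\CCCC(=O)OC` follows from compound 2 by one change: iodo in place of bromo on a double-bonded ring carbon. For the measured compounds named here, no measured pair isolates this swap, so the expectation in this assay is no step beyond the scatter, with a slight lean towards weaker inhibition. The expected 1.4-fold higher number from compound 2 to compound 3 (0.15 log units; within the scatter) is small. Compound 3 is estimated at 700 nM, with an expected range of 250 nM to 2200 nM.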

Compound 3, half-maximal inhibitory concentration: 6700 nM
Compound 3: the middle estimate sits 9.6-fold (0.98 log units) below what was measured; the whole stated range lies below it.
By their numbers in this assay, from the lowest: compound 2; then compounds 1 and 3 (each within the scatter of the next).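

At the double-bonded ring carbon, the bromo-to-iodo swap is not neutral: in this assay it gives a 13-fold higher number from compound 2 to compound 3 (1.13 log units; beyond the scatter) and so marks this position as sensitive to the halogen it carries. The double bond configuration, by contrast, gives a 1.7-fold higher number from compound 1 to compound 3 (0.24 log units; within the scatter) among the iodo compounds, so no separation appears there. That second step reads one feature alone: the fact that compounds 1 and 3 differ only in the configuration as drawn

Open, on these data alone, is whether chloro or a nitrile at this ring carbon would track compound 2 or compound 3. Also open, as far as these compounds go, is whether the double bond configuration would matter as little with bromo in place.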